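Extending the chain-end aryl group toward a thiophene

This account rests on a few compounds, and the source may have more. Where it says the series, first, only, none or still open, it means among the compounds named here.

Compound 1 `O=C1N(CCCCCCOc2ccc(F)cc2)CCN1c1ccncc1` and compound 2 `CSc1ccc(OCCCCCCN2CCN(c3ccncc3)C2=O)cc1` share a core and differ only in the group on the aromatic ring at the end of the chain. In a functional assay on cells (Homo sapiens) for cytotoxicity (on this read-out lower numbers stand for higher toxicity in this test and higher numbers for lower toxicity in this test), compound 1 gives > 25000 nM, which is a limit of the assay rather than a number. In this assay compound 2 gives > 25000 nM, likewise a limit of the assay and not a number. The step from compound 1 to compound 2 is therefore a step that the two limits leave unreadable from compound 1 to compound 2, and both values sit at the limit of > 25000 nM in this assay, at which 2 of the 2 values shown sit.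

Compound 3 `O=C1N(CCCCCCOc2ccc(-c3cccs3)cc2)CCN1c1ccncc1` is not yet measured. It differs from compound 2 in one place: thiophen-2-yl in place of methylsulfanyl on an aromatic carbon. Among the compounds with values here, the only measured step bears on the same position of the same core, but its size is not readable, so no direction can be drawn from it. The expectation for compound 3 is thus that it behaves like compound 2, and its value in this assay is estimated at 25000 nM, with a range from 8000 nM to 60000 nM. The step from compound 2 to compound 3 that this estimate means is expected to be a number no higher from compound 2 to compound 3 (the limit leaves the size open).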

Compound 3, half-maximal cytotoxic concentration: > 25000 nM
Compound 3 ended at the assay's limit; the forecaster's own chance of this, stated with the estimate: 60%; the middle value lies on the limit itself.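

Compound 1, compound 2 and compound 3 all sit at one limit of this assay, so no step among them can be read: the limit of > 25000 nM in this assay, at which 3 of the 3 values shown sit.

The compounds shown leave open how far each one lies past that limit, and whether any group at this end of the chain would give a readable number.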